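Adding a Second Methoxy Group to an Amylase Inhibitor

The compounds below may be only part of what the source reports. "The series", "measured", "known", "first", "only" and "open" are said of these compounds alone.

Measured so far:
compound 1, `COc1ccccc1/C=C1/C(=O)N(c2ccc(Cl)cc2)N=C1C`: 2020 nM
compound 2, `COc1ccc(/C=C2/C(=O)N(c3ccc(Cl)cc3)N=C2C)c(OC)c1`: 2010 nM

Both compounds were tested in an assay for inhibition of Alpha amylase (Homo sapiens), with a stated time of 10 min; a lower number here means a stronger inhibitor, a higher number a weaker inhibitor. Compound 1 gives 2020 nM, and compound 2 gives 2010 nM. These two numbers sit within the scatter of each other, so nothing separates the two compounds on the evidence at hand.

The unmeasured compound 3, `COc1ccc(OC)c(/C=C2/C(=O)N(c3ccc(Cl)cc3)N=C2C)c1`, is derived from compound 1 by one change: methoxy in place of hydrogen on an aromatic carbon. Among the measured compounds shown here, the only step that bears on this change is the one from compound 1 to compound 2, where a methoxy group also took the place of a hydrogen on the same ring, at a different position: a 1.0-fold lower number from compound 1 to compound 2 (0.00 log units; within the scatter). That step left the number essentially unchanged.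

On this one comparison, a methoxy group entering the ring of compound 1 is expected to make no difference in this assay beyond the scatter, so compound 3 is expected to show a step of a 1.0-fold lower number from compound 1 to compound 3 (0.00 log units; within the scatter). The estimate for compound 3 is 2000 nM, within a range from 900 nM to 4500 nM.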

Compound 3, half-maximal inhibitory concentration: 2130 nM
For compound 3 the middle estimate is 1.1-fold (0.03 log units) below the measured one; low and high end bracket the measured number.
By their numbers in this assay, from the lowest: compounds 2, 1 and 3 (each within the scatter of the next).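

The new methoxy group sits on an aromatic carbon meta to a large group and para to a methoxy group, and in this assay this change gives a 1.1-fold higher number from compound 1 to compound 3 (0.02 log units; within the scatter) and stays within the scatter. Taken with the one earlier case, a 1.0-fold lower number from compound 1 to compound 2 (0.00 log units; within the scatter), this makes two different ring positions where a methoxy group in place of hydrogen has produced no change beyond the scatter, so the earlier result no longer stands alone. No measurement at hand explains why the number holds steady or shows what the added methoxy group does at this position.

Among the compounds shown here, the only group entering the ring in these compounds is methoxy, so it remains open whether an amine, a carboxylic acid or a longer chain at this same position would shift the number beyond the scatter. From the compounds shown here alone, it also remains open whether changes elsewhere on the core of compound 1 would leave the number as steady as these two methoxy steps did.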